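Amide nitrogen substituents on a shared core

The source may hold more compounds than are shown below. What is called first, only, known or untested is meant among the compounds shown, and "the series" means these compounds.

Measured compounds:
compound 1 `COc1ccc(/C=C/c2cc(OC)cc(OC)c2/C=C/C(=O)NC2CC2)cc1` — 3940 nM
compound 2 `COc1ccc(/C=C/c2cc(OC)cc(OC)c2/C=C/C(=O)N2CCN(C)CC2)cc1` — 2290 nM
compound 3 `C#CCNC(=O)/C=C/c1c(/C=C/c2ccc(OC)cc2)cc(OC)cc1OC` — 4560 nM

All three were read in a functional assay on MCF7 cells (Homo sapiens) for inhibition, read by MTT assay, with a stated time of 48 h; a lower number here means a stronger inhibitor, a higher number a weaker inhibitor. Compound 1 stands second highest of the three numbers; its nearest neighbour is compound 3, with a 1.2-fold higher number from compound 1 to compound 3 (0.06 log units; within the scatter), and its furthest is compound 2, with a 1.7-fold lower number from compound 1 to compound 2 (0.24 log units; within the scatter). Every step among the three lies within the scatter, including a 2.0-fold higher number from compound 2 to compound 3 (0.30 log units; within the scatter).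

Compound 4 `CCNC(=O)/C=C/c1c(/C=C/c2ccc(OC)cc2)cc(OC)cc1OC` is not yet measured. The change from compound 1 is ethyl in place of cyclopropyl on an amide-type nitrogen. The step that bears on it most closely is the exchange of groups on the same amide-type nitrogen, a 1.2-fold higher number from compound 1 to compound 3 (0.06 log units; within the scatter), which did not move the number beyond the scatter. No step beyond the scatter is therefore expected for a 1.0-fold higher number from compound 1 to compound 4 (0.01 log units; within the scatter). Compound 4 is estimated at 4000 nM, within 2000 nM to 8000 nM.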

Compound 4, half-maximal inhibitory concentration: 7060 nM
Compound 4: the middle estimate sits 1.8-fold (0.25 log units) below what was measured, and the stated range covers the measured number.
By their numbers in this assay, from the lowest: compounds 2, 1, 3 and 4 (each within the scatter of the next, the first and the last beyond it).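

Ethyl in place of cyclopropyl on the amide-type nitrogen stays within the scatter in this assay (a 1.8-fold higher number from compound 1 to compound 4 (0.25 log units; within the scatter)), as does methyl in place of ethynyl on the saturated chain carbon (a 1.5-fold higher number from compound 3 to compound 4 (0.19 log units; within the scatter)). Ethylamino in place of 4-methylpiperazin-1-yl on the carbonyl carbon gives the first step beyond the scatter in this set, a modest one (a 3.1-fold higher number from compound 2 to compound 4 (0.49 log units; beyond the scatter)). Nothing available explains this separation. From the compounds shown here alone, whether a longer chain ending in an amine or a carboxylic acid on this nitrogen would shift the number remains open.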